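Swapping a branched alkyl chain for a phenyl-bearing one

The source may report more compounds than this note shows. Statements on the series, on what has been measured and on what is new or still open speak of the compounds shown alone.

Of the compounds shown here, three sharing one core have so far been tested in a functional assay for inhibition of Polyunsaturated fatty acid 5-lipoxygenase (Homo sapiens); on this read-out higher numbers stand for weaker inhibition and lower numbers for stronger inhibition. Compound 1 `O=C(O)CSC(CCCc1ccc(Cl)cc1)c1ccc(OCc2ccc3ccccc3n2)cc1` gives 7 nM. Compound 2 `CCCCC(CCCC)C(O/N=C/C(=O)O)c1ccc(OCc2ccc3ccccc3n2)cc1` gives 10 nM. Compound 3 `CCCCC(CCCC)C(O/N=C(\C)C(=O)O)c1ccc(OCc2ccc3ccccc3n2)cc1` gives 14 nM; it carries the highest of the three numbers, yet compound 2 lies within the scatter of it, and so does compound 1, so no order among them can be claimed. Among the measured compounds shown here, the only single-place step measured, a 1.4-fold higher number from compound 2 to compound 3 (0.15 log units; within the scatter), changes the group on the oxime oxygen and leaves the side chain untouched. Compound 4 `C/C(=N\OC(CC(C)(C)c1ccccc1)c1ccc(OCc2ccc3ccccc3n2)cc1)C(=O)O` differs from compound 3 elsewhere: 2-methyl-2-phenylpropyl in place of 1-butylpentyl on a saturated chain carbon bound to an aromatic carbon and an oxygen on an unsaturated carbon. For the measured compounds named here, no measured step speaks to this position. Going by the values given here, the one hint comes from compound 1, whose side chain also holds a phenyl ring and whose number sits within the scatter of compound 3. The change is therefore expected to bring a step of a 1.2-fold lower number from compound 3 to compound 4 (0.07 log units; within the scatter) of no size beyond the scatter in this assay. Compound 4 is estimated at 12 nM, within a range from 4 nM to 40 nM.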

Compound 4, half-maximal inhibitory concentration: 22 nM
Compound 4: middle estimate off by 1.8-fold (0.26 log units), on the low side; the measured number falls inside the stated range.
By their numbers in this assay, from the lowest: compounds 1, 2, 3 and 4 (each within the scatter of the next, the first and the last beyond it).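

In this assay, the swap of 1-butylpentyl for 2-methyl-2-phenylpropyl gives a 1.6-fold higher number from compound 3 to compound 4 (0.20 log units; within the scatter), the only step shown at this position, and it stays within the scatter. For this one pair, then, a branched alkyl chain and a chain carrying a six-membered aromatic ring cannot be told apart by this read-out, so the ring can stand at this position without a change beyond the scatter. No evidence is at hand to explain this result.

Going by these compounds, it remains open whether a much shorter group such as ethyl, or a chain ending in an amine or a hydroxyl group, would bring a step beyond the scatter at this position. On these data alone, it is also open whether the same swap would give a similar step with the group on the oxime oxygen of compound 2.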